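Piperidine nitrogen substituent and maximal response at the incretin receptor

The compounds below may be only part of what the source reports. "The series", "measured", "known", "first", "only" and "open" are said of these compounds alone.

Compound 1: `CC(C)(C)COC(=O)N1CCC(Oc2ncnc3c2CCN3c2ccc(S(C)(=O)=O)cc2F)CC1` — 80%
Compound 2: `CN(C)S(=O)(=O)N1CCC(Oc2ncnc3c2CCN3c2ccc(S(C)(=O)=O)cc2F)CC1` — 68%

Of the compounds shown here, two sharing one core have been measured in a functional assay on CHO-K1 cells with Glucose-dependent insulinotropic receptor (Homo sapiens) as the target, read by a luciferase reporter, with a stated time of 5 h; a higher number here means a larger maximal response, a lower number a smaller maximal response. Compound 1 gives 80%, and compound 2 gives 68%, so compound 2 stands lowest of the two. Within the data shown here, the only step measured so far, a number 12 percentage points lower from compound 1 to compound 2 (beyond the scatter), concerns the same amine nitrogen in a ring that is changed on the way to compound 3, `CC(C)c1noc(N2CCC(Oc3ncnc4c3CCN4c3ccc(S(C)(=O)=O)cc3F)CC2)n1`. The change is 3-isopropyl-1,2,4-oxadiazol-5-yl in place of dimethylsulfamoyl on an amine nitrogen in a ring.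

That one step shows that swapping the group on this nitrogen moves the maximal response only modestly. Among the measured compounds shown here, no measured compound carries an aromatic group there, so the direction for compound 3 is open. Compound 3 is therefore expected to land between its two neighbours, with a number 6 percentage points higher from compound 2 to compound 3 (within the scatter) as the expected step. The estimate for compound 3 is 74%, with a range from 55% to 92%.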

Compound 3, largest response reached (reported as percent of maximum), in percent of the reference or control that the assay uses: 124%
For compound 3 the middle estimate is 50 percentage points below the measured one; measured number above the stated range.
By their numbers in this assay, from the lowest: compound 2; then compound 1; then compound 3.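

In this assay, the amine nitrogen in the six-membered ring turns out to allow much more than the modest shift seen so far: 3-isopropyl-1,2,4-oxadiazol-5-yl gives a number 56 percentage points higher from compound 2 to compound 3 (beyond the scatter) and also a number 44 percentage points higher from compound 1 to compound 3 (beyond the scatter) when it replaces neopentyloxycarbonyl. The group on this nitrogen can therefore change the maximal response by a large amount, and among the three compounds this five-membered aromatic ring with 3 hetero atoms gives the largest response, beyond the scatter from both other groups. No measurement at hand explains the gain.

Whether it comes from the aromatic ring or from its isopropyl group remains open, with only this one ring shown on the nitrogen. A methyl or cyclopropyl group in place of isopropyl, or a pyrimidine ring in place of the oxadiazole, would help to separate the two.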